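This account rests on a few compounds, and the source may have more. Where it says the series, first, only, none or still open, it means among the compounds named here.

Working notes on the thienopyrimidine urea series, cytotoxicity read-out.

Of the compounds shown here, three have been measured in a functional assay on MDA-MB-231 cells (Homo sapiens) for cytotoxicity, read by MTT assay, with a stated time of 72 h; on this read-out higher numbers stand for weaker inhibition and lower numbers for stronger inhibition. Compound 1 `CCN(CC)CCCNc1nc(-c2ccc(NC(=O)Nc3ccc(F)cc3)cc2)nc2c(Cl)c(Cl)sc12` gives 1630 nM. Compound 3 `CCN(CC)CCNc1nc(-c2ccc(NC(=O)Nc3ccc(F)cc3)cc2)nc2c(Cl)c(Cl)sc12` gives 1130 nM. Compound 2 `CCN(CC)CCCNc1nc(-c2ccc(NC(=O)Nc3ccccc3F)cc2)nc2ccsc12` gives 860 nM. All three numbers sit close together, and none of the gaps between them is large enough to be read as a difference in potency. Compound 4 `CCN(CC)CCNc1nc(-c2ccc(NC(=O)Nc3ccccc3F)cc2)nc2ccsc12` has not yet been run in this assay.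

Compound 1 and compound 3 share one core and differ in a single place: diethylamino in place of (diethylamino)methyl on a saturated chain carbon, two bonds along the chain from a nitrogen on an aromatic ring. The measured outcome of that change is a 1.4-fold lower number from compound 1 to compound 3 (0.16 log units; within the scatter), which is a small step.

The core of compound 2 is not the core of compound 1; the difference between the two cores is not broken down here, and what the two values of compound 1 and compound 2 show is only that they lie within the usual range of each other.

Compound 4 is obtained from compound 2 by the same change: diethylamino in place of (diethylamino)methyl on a saturated chain carbon, two bonds along the chain from a nitrogen on an aromatic ring. Going by the values given here, the place of the change is the same as in the pair of compound 1 and compound 3, so the one precedent in this assay applies directly. Among the compounds with values here, the expected step is a 1.2-fold lower number from compound 2 to compound 4 (0.09 log units; within the scatter), resting on the single precedent of a 1.4-fold lower number from compound 1 to compound 3 (0.16 log units; within the scatter) and on the expectation that a chain shortening of this kind again moves the number only a little. Compound 4 is therefore expected to give about 700 nM in this assay. The plausible range for compound 4 is estimated as 350 nM to 1400 nM.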

Compound 4, half-maximal inhibitory concentration: 580 nM
Compound 4: middle estimate off by 1.2-fold (0.08 log units), on the high side; low and high end bracket the measured number.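

In this assay, the new step reads a 1.5-fold lower number from compound 2 to compound 4 (0.17 log units; within the scatter) and so stays within the usual scatter, as does the earlier step on the core of compound 1. Diethylamino in place of (diethylamino)methyl therefore carries from one core to the other with no visible difference in the size of the step: the same change on two cores in this assay, a 1.4-fold lower number (0.16 log units; within the scatter) from compound 1 to compound 3 and a 1.5-fold lower number (0.17 log units; within the scatter) from compound 2 to compound 4, 1.0-fold (0.01 log units) apart, within the scatter of two such steps. Going by these compounds alone, this shows that on these two cores the change leaves the number within the scatter, but it does not establish a real effect of the change in either direction, and with only two pairs, each resting on one step, it does not show that the same would hold on any other core.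

From the compounds shown here alone, all four compounds end in diethylamino and carry only the 3-(diethylamino)propyl or the 2-(diethylamino)ethyl chain, so it remains open how a longer chain, or a cyclic amine such as morpholine or piperidine at the chain end, would read in this assay. Also open is what each difference between the core of compound 1 and the core of compound 2 contributes alone, since the compounds shown do not separate those differences.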